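The source may hold more compounds than are shown below. What is called first, only, known or untested is meant among the compounds shown, and "the series" means these compounds.

Measured in a functional assay on 143B cells (Homo sapiens) for antiproliferative activity, read by MTT assay, with a stated time of 48 h; a higher number here means a weaker inhibitor, a lower number a stronger inhibitor:

Compound 1 `O=C(Nc1cccc(/C=C/C(=O)c2nc3ccccc3[nH]2)c1)c1ccc(Br)cc1` gives 7310 nM
Compound 2 `Cc1ccccc1C(=O)Nc1cccc(/C=C/C(=O)c2nc3ccccc3[nH]2)c1` gives 8290 nM
Compound 3 `Cc1ccc(C(=O)Nc2cccc(/C=C/C(=O)c3nc4ccccc4[nH]3)c2)cc1` gives 6560 nM

All three share the same core and differ only in the aromatic group attached to the carbonyl carbon of the amide. Their numbers sit close together: a 1.1-fold higher number from compound 1 to compound 2 (0.05 log units; within the scatter), a 1.1-fold lower number from compound 1 to compound 3 (0.05 log units; within the scatter) and a 1.3-fold lower number from compound 2 to compound 3 (0.10 log units; within the scatter) are each within the scatter, so compound 3 stands at the low end of the three without being separable from the others.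

Compound 4 `O=C(Nc1cccc(/C=C/C(=O)c2nc3ccccc3[nH]2)c1)c1cc(Cl)cc(Cl)c1` carries the change (3,5-dichlorophenyl in place of 4-methylphenyl on a carbonyl carbon). The measured steps all concern swaps on this same ring, bromo for methyl and 2-methylphenyl for 4-methylphenyl, and none of them moved the number beyond the scatter. Among the compounds with values here, no measured compound carries two chlorines on this ring, so the expectation rests on those small steps. In this assay compound 4 is therefore expected to show no step beyond the scatter, a 1.1-fold higher number from compound 3 to compound 4 (0.03 log units; within the scatter). The estimate for compound 4 is 7000 nM, with a range from 3500 nM to 14000 nM.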

Compound 4, half-maximal inhibitory concentration: 3660 nM
Estimate against measurement, compound 4: 1.9-fold (0.28 log units) above; the range from low to high includes it.
By their numbers in this assay, from the lowest: compounds 4, 3, 1 and 2 (each within the scatter of the next, the first and the last beyond it).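

Within the data shown here, this position on the carbonyl carbon of the amide had so far produced only steps within the scatter, and 3,5-dichlorophenyl gives the first step beyond it: a 2.3-fold lower number from compound 2 to compound 4 (0.36 log units; beyond the scatter) in place of 2-methylphenyl. Against the other two rings the change stays within the scatter, with a 1.8-fold lower number from compound 3 to compound 4 (0.25 log units; within the scatter) and a 2.0-fold lower number from compound 1 to compound 4 (0.30 log units; within the scatter) on the same swap, so the group separates compound 4 from compound 2 only, and by a modest margin. Nothing measured here gives a reason for that difference.

Whether both chlorines are needed remains open, as a ring with a single chlorine on it is not among these compounds. So does the behaviour of this position with an amine, a carboxylic acid or a longer chain on the ring.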